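Step from compound 3 to compound 4 on the adenosine receptor

The source may hold more compounds than are shown below. What is called first, only, known or untested is meant among the compounds shown, and "the series" means these compounds.

The shared core of compound 3 `CNC(=O)[C@@]12C[C@@H]1[C@@H](n1cnc3c(NCc4cccc(Cl)c4)nc(C#CCCCCc4cn(CCCCN)nn4)nc31)[C@H](O)[C@@H]2O` is measured in an assay on CHO cells for displacement of a labelled ligand from adenosine receptor A1 (Homo sapiens), read by scintillation counting, tested at 10 uM (on this read-out lower numbers stand for less inhibition and higher numbers for more inhibition at the one concentration tested (going by the name of the read-out)), where compound 3 gives 13%. Among the three measured compounds, compound 3 stands second highest. Its nearest neighbour is compound 1 `CNC(=O)[C@@]12C[C@@H]1[C@@H](n1cnc3c(NCc4cccc(Cl)c4)nc(C#CCCCCc4cn(-c5ccc(N)cc5)nn4)nc31)[C@H](O)[C@@H]2O`, which in this assay gives 3%; its furthest is compound 2 `C#CCCCC#Cc1nc(NCc2cccc(Cl)c2)c2ncn([C@@H]3[C@H](O)[C@H](O)[C@]4(C(=O)NC)C[C@H]34)c2n1`, which gives 36%.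

Compound 4 `CNC(=O)[C@@]12C[C@@H]1[C@@H](n1cnc3c(NCc4cccc(Cl)c4)nc(C#CCCCCc4cn(Cc5ccc(-n6sccc6=O)cc5)nn4)nc31)[C@H](O)[C@@H]2O` differs from compound 3 at the substituent on the aromatic nitrogen: a group of 12 heavy atoms (9 carbon, 1 nitrogen, 1 oxygen, 1 sulfur; one five-membered aromatic ring with 2 hetero atoms, one six-membered aromatic ring of carbon only) in place of a group of 4 heavy atoms (3 carbon, 1 nitrogen; no ring), on a saturated chain carbon bound to an aromatic nitrogen.

Among the measured compounds shown here, the one measured step at this place is a number 10 percentage points higher from compound 1 to compound 3 (within the scatter), where a 4-aminobutyl stands in for a 4-aminophenyl on the aromatic nitrogen. That step lies within the scatter, so the data at this position show no movement beyond the scatter. For the measured compounds named here, compound 2, which carries no group of this kind at all, is the only one beyond the scatter, and no step is computed to it. A small step is therefore expected, if any: a number 3 percentage points lower from compound 3 to compound 4 (within the scatter) is the estimated change from compound 3 to compound 4. Compound 4 is estimated to give 10% in this assay, within a range from 0% to 28%.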

Compound 4, a percentage reported as inhibition, at one concentration (the size of the read-out at that concentration, not a potency): 15%
For compound 4 the middle estimate is 5 percentage points below the measured one; low and high end bracket the measured number.
By their numbers in this assay, from the lowest: compounds 1, 3 and 4 (each within the scatter of the next, the first and the last beyond it); then compound 2.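

In this assay, the substituent on the aromatic nitrogen can now be changed far more drastically without a reading beyond the scatter: a number 2 percentage points higher from compound 3 to compound 4 (within the scatter), although the entering group carries two aromatic rings and no hydrogen-bond donor. The earlier step at this place, a number 10 percentage points higher from compound 1 to compound 3 (within the scatter), only exchanged one amine-bearing group for another, so it could not show that the read-out also stays within the scatter when the amine is replaced by a much larger group without one. No measurement shown gives a reason for this result.

The compounds shown leave open whether a carboxylic acid at the end of the chain, or a plain benzyl group on that nitrogen, would stay equally close to compound 3. They also leave open whether a longer chain would do so in this assay at the one concentration tested.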